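Benzyloxy variation on a trimethoxyphenyl chromone core

A few compounds are considered here, and "the series" means these few. Any claim that something is new, unique, unknown or untested is made for them only; others in the source may bear on it.

Measured compounds in a functional assay on HepG2 cells (Homo sapiens) for antiproliferative activity, read by MTT assay, with a stated time of 24 h; on this read-out lower numbers stand for stronger inhibition and higher numbers for weaker inhibition:
- compound 1, `COc1cc(OC)c(-c2coc3cc(OCc4ccc(F)cc4)ccc3c2=O)cc1OC`, gives 1000 nM
- compound 2, `COc1cc(OC)c(-c2coc3cc(OCc4ccccc4C)ccc3c2=O)cc1OC`, gives 1860 nM
- compound 3, `COc1cc(OC)c(-c2coc3cc(OCc4ccccc4Cl)ccc3c2=O)cc1OC`, gives 1690 nM

Compound 2 sits at the highest number of the three, but its gaps to the others are small: the step of a 1.9-fold higher number from compound 1 to compound 2 (0.27 log units; within the scatter) and the step of a 1.1-fold lower number from compound 2 to compound 3 (0.04 log units; within the scatter) both fall within the scatter, as does a 1.7-fold higher number from compound 1 to compound 3 (0.23 log units; within the scatter). On these numbers the three compounds are indistinguishable in this assay.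

Compound 4, `COc1cc(OC)c(-c2coc3cc(OCc4ccc(C(F)(F)F)cc4)ccc3c2=O)cc1OC`, is not yet measured. Relative to compound 2 the change is 4-(trifluoromethyl)phenyl in place of 2-methylphenyl on a saturated chain carbon bound to an oxygen on an aromatic ring. Among the measured compounds shown here, the one step that bears on it is the swap from a substituent at one position of the benzyl ring to another, a 1.9-fold higher number from compound 1 to compound 2 (0.27 log units; within the scatter), which stayed within the scatter; the step of a 1.1-fold lower number from compound 2 to compound 3 (0.04 log units; within the scatter) likewise shows no movement. Nothing here suggests a step beyond the scatter for compound 4, and the estimated step of a 1.4-fold lower number from compound 2 to compound 4 (0.16 log units; within the scatter) is expected to stay inside it. Compound 4 is expected to give about 1300 nM in this assay, with a range from 600 nM to 3000 nM.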

Compound 4, half-maximal inhibitory concentration: 890 nM
Beside the measured number, compound 4's estimate is 1.5-fold (0.16 log units) above it, within the range that was stated.
By their numbers in this assay, from the lowest: compounds 4, 1, 3 and 2 (each within the scatter of the next, the first and the last beyond it).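

In this assay, among the compounds shown here, 4-(trifluoromethyl)phenyl in place of 2-methylphenyl on the saturated chain carbon gives the only step in the set that passes the scatter, a 2.1-fold lower number from compound 2 to compound 4 (0.32 log units; beyond the scatter), and that step is modest. The separation stops at this one pair: a 1.9-fold lower number from compound 3 to compound 4 (0.28 log units; within the scatter) and a 1.1-fold lower number from compound 1 to compound 4 (0.05 log units; within the scatter) leave 4-(trifluoromethyl)phenyl unresolved from both 2-chlorophenyl and 4-fluorophenyl, and compound 3 and compound 1 therefore go against any clean split by substituent. No measurement available here accounts for the step from 2-methylphenyl to 4-(trifluoromethyl)phenyl.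

Open, from the compounds shown here alone, is whether that step follows the position or the group: 2-methylphenyl and 4-(trifluoromethyl)phenyl differ in both. Also open, going by these compounds, is how an amine or a carboxylic acid on the phenyl ring, or a longer chain to it, would read in this assay.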